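A Methyl on the Ring Amine of Compound 2

The compounds below may be only part of what the source reports. "The series", "measured", "known", "first", "only" and "open" are said of these compounds alone.

Of the compounds shown here, three built on a shared bridged bicyclic amine have been measured in an in vitro functional assay on SH-EP1 cells for agonist activity at Neuronal acetylcholine receptor; alpha4/beta2 (Homo sapiens), read by FLIPR and calcium flux; on this read-out higher numbers stand for larger maximal responses and lower numbers for smaller maximal responses. Compound 1 `Clc1ccc(C2=CC3CNCC(C2)C3)cn1` gives 152% in this assay. Compound 2 `Fc1ccc(C2=CC3CNCC(C2)C3)cn1` gives 136%, and compound 3 `C1=C(c2cccnc2)C[C@@H]2CNC[C@H]1C2` gives 131%. Among the measured compounds shown here, the one step between compounds that differ in a single place, the exchange of fluoro for chloro on the aromatic carbon, is a number 16 percentage points lower from compound 1 to compound 2 (beyond the scatter). Among the three numbers, compound 2 stands second; compound 3 lies within the scatter of it, while compound 1 lies beyond the scatter, higher.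

Compound 4 `CN1CC2C=C(c3ccc(F)nc3)CC(C2)C1` differs from compound 2 by methyl in place of hydrogen on an amine nitrogen in a ring. For the measured compounds named here, no measured pair touches the amine nitrogen, so no step among the three measured compounds bears directly on this change; the only measured step concerns the halogen on the pyridine ring and is modest. The data therefore give no footing for a directional expectation, and a step of about a number 11 percentage points lower from compound 2 to compound 4 (beyond the scatter) is estimated, which would sit within the scatter. For compound 4 the expected value in this assay is 125%, with a range from 85% to 160%.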

Compound 4, largest response reached (reported as percent of maximum), in percent of the reference or control that the assay uses: 9.4%
The estimate for compound 4 lay 115.6 percentage points above the measured number; measured number below the stated range.
By their numbers in this assay, from the lowest: compound 4; then compounds 3 and 2 (each within the scatter of the next); then compound 1.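

Among the compounds shown here, the ring amine nitrogen, which no earlier pair touched, proves far more sensitive in this assay than the one position probed before. Methyl in place of hydrogen on this amine nitrogen in a ring gives a number 126.6 percentage points lower from compound 2 to compound 4 (beyond the scatter) and is a large step, whereas the halogen exchange gives a number 16 percentage points lower from compound 1 to compound 2 (beyond the scatter) and is only a modest one. So the addition of a single carbon at this position is enough to leave compound 4 with only a small maximal response, and nothing available accounts for the size of this drop.

On these data alone, it remains open whether the loss is specific to methyl or would extend to an ethyl group, a longer chain or an acetyl group on the same nitrogen. As far as these compounds go, it is also open whether the same change would have a comparable effect with the chloro group of compound 1 or on the pyridine without a halogen in compound 3.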